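Hydroxy to amino on two triazole regioisomers

This account rests on a few compounds, and the source may have more. Where it says the series, first, only, none or still open, it means among the compounds named here.

Measured so far in a functional assay on K562 cells (Homo sapiens) for cytotoxicity, read by MTT assay, with a stated time of 5 days; on this read-out higher numbers stand for weaker inhibition and lower numbers for stronger inhibition:
compound 1, `COc1ccc(-c2cnnn2Cc2cc(OC)c(OC)c(OC)c2)cc1O`, gives 530 nM
compound 2, `COc1ccc(-c2cnnn2Cc2cc(OC)c(OC)c(OC)c2)cc1N`, gives 380 nM
compound 3, `COc1ccc(-c2cn(Cc3cc(OC)c(OC)c(OC)c3)nn2)cc1O`, gives > 10000 nM

Compound 1 and compound 2 share a core and differ only by amino in place of hydroxy on an aromatic carbon. In this assay that change gives a 1.4-fold lower number from compound 1 to compound 2 (0.14 log units; within the scatter), so the two values are not told apart by this read-out. Compound 3 has the same atoms as compound 1, joined differently; the difference between the two cores is not broken down here. For compound 3 the result in this assay is a limit of the assay and not a number, > 10000 nM. This is the limit of > 10000 nM in this assay, at which 1 of the 3 values shown sits.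

Compound 4, `COc1ccc(-c2cn(Cc3cc(OC)c(OC)c(OC)c3)nn2)cc1N`, is not yet measured. It differs from compound 3 by amino in place of hydroxy on an aromatic carbon. This is the same change as that made from compound 1 to compound 2; among the compounds shown it occurs two times in all. The expectation for compound 4 in this assay rests on the measured step of a 1.4-fold lower number from compound 1 to compound 2 (0.14 log units; within the scatter), which lay within the scatter, and on the limit held by compound 3. The step expected on that basis is a number no higher from compound 3 to compound 4 (the limit leaves the size open). Compound 4 is therefore estimated at 10000 nM in this assay, with a considerable chance that the assay again reports only a limit.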

Compound 4, half-maximal inhibitory concentration: > 10000 nM
Compound 4: only a limit was reported; the forecaster's own chance of this, stated with the estimate: 70%; the middle value lies on the limit itself.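

In this assay compound 4 gives > 10000 nM, a limit of the assay and not a number. Compound 3 also stands at a limit, so no step can be read between compound 3 and compound 4: the limit of > 10000 nM in this assay, at which 2 of the 4 values shown sit. The compounds shown leave open whether amino in place of hydroxy changes anything on the core of compound 3.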